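The source may hold more compounds than are shown below. What is called first, only, known or untested is meant among the compounds shown, and "the series" means these compounds.

Compound 1 `COc1cc(/C=C/C(=O)O)ccc1OC(=O)c1nc(C)c(C)nc1C`: 69400 nM
Compound 2 `COc1ccc(OC(=O)c2nc(C)c(C)nc2C)c(/C=C/C(=O)O)c1`: 48600 nM
Compound 3 `COc1cc(/C=C/C(=O)O)cc(OC)c1OC(=O)c1nc(C)c(C)nc1C`: 34700 nM

These values come from a functional assay on EA.hy 926 cells (Homo sapiens) for cytotoxicity, read by MTT assay, with stated times of 24 h and 12 h; on this read-out lower numbers stand for an effect already at smaller amounts and higher numbers for an effect only at larger amounts of compound. Compound 3, at 34700 nM, lies within the scatter of both other compounds, so it cannot be set apart from them. Compound 4 `CCOC(=O)/C=C/c1cc(OC)c(OC(=O)c2nc(C)c(C)nc2C)c(OC)c1` differs from compound 3 in one place: ethyl in place of hydrogen on an oxygen next to a carbonyl group, which turns carboxy into ethoxycarbonyl. Among the measured compounds shown here, the only measured step, a 2.0-fold lower number from compound 1 to compound 3 (0.30 log units; within the scatter), is a different change, methoxy in place of hydrogen on an aromatic carbon. For the measured compounds named here, no measured pair covers the new change, so the direction stays open, and no step beyond the scatter is expected in this assay, though with wide uncertainty. The expected step is a 1.2-fold lower number from compound 3 to compound 4 (0.06 log units; within the scatter). For compound 4 the estimated value is 30000 nM, with an expected range of 9000 nM to 100000 nM.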

Compound 4, half-maximal effective concentration: 21400 nM
Estimate against measurement, compound 4: 1.4-fold (0.15 log units) above; the range from low to high includes it.
By their numbers in this assay, from the lowest: compounds 4, 3, 2 and 1 (each within the scatter of the next, the first and the last beyond it).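

Compounds 1 to 3 all carry a carboxy group, so the place where compound 4 differs had not yet been tested. In this assay, turning carboxy into ethoxycarbonyl gives a 1.6-fold lower number from compound 3 to compound 4 (0.21 log units; within the scatter) and so leaves the number within the usual scatter. The carboxy hydrogen is therefore not needed for an effect of this size, and no measurement on hand explains the result. Going by these compounds, whether a methyl group or a longer chain on that oxygen, or an amide in place of the ester, would move the number beyond the scatter stays open. So does whether the same change would behave alike on compound 1 or compound 2.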